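Phenoxy in place of the chlorinated biaryl terminus

This account rests on a few compounds, and the source may have more. Where it says the series, first, only, none or still open, it means among the compounds named here.

Compound 3 `Cc1ccc(-c2cccc(COc3ccc(S(=O)(=O)CC(=O)O)cc3)c2)c(Cl)c1` gives 36.3 nM in a functional assay on CHO cells for agonist activity at Free fatty acid receptor 1 (Homo sapiens), read by FLIPR and calcium flux (a lower number here means that less compound is needed, a higher number that more compound is needed for the effect), the second highest of the three numbers; nearest stands compound 2 `O=C(O)CS(=O)(=O)c1ccc(OCc2cccc(-c3ccccc3Cl)c2)cc1` with 28.8 nM, furthest compound 1 `O=C(O)CS(=O)(=O)c1ccc(OCc2cccc(-c3ccccc3F)c2)cc1` with 257 nM. Compound 4 `O=C(O)CS(=O)(=O)c1ccc(OCc2cccc(Oc3ccccc3)c2)cc1` carries phenoxy in place of 2-chloro-4-methylphenyl on an aromatic carbon. Among the measured compounds shown here, no measured step exchanges the terminal ring itself for a phenoxy; the measured steps only vary substituents on that ring: an 8.9-fold lower number from compound 1 to compound 2 (0.95 log units; beyond the scatter) and a 7.1-fold lower number from compound 1 to compound 3 (0.85 log units; beyond the scatter) were modest and beyond the scatter, while a 1.3-fold higher number from compound 2 to compound 3 (0.10 log units; within the scatter) stayed within it. Both compounds with the lower numbers carry the chloro that compound 4 lacks, so a higher number is expected, with wide uncertainty in either direction. Compound 4 is estimated at 150 nM, range 30 nM to 800 nM. The expected step is a 4.1-fold higher number from compound 3 to compound 4 (0.62 log units; beyond the scatter).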

Compound 4, half-maximal effective concentration: 97.7 nM
For compound 4 the middle estimate is 1.5-fold (0.19 log units) above the measured one, within the range that was stated.
By their numbers in this assay, from the lowest: compounds 2 and 3 (each within the scatter of the next); then compound 4; then compound 1.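

In this assay the position accepts a phenoxy in place of a directly attached substituted phenyl, and the direction of the change depends on the group replaced: a 2.7-fold higher number from compound 3 to compound 4 (0.43 log units; beyond the scatter) and a 3.4-fold higher number from compound 2 to compound 4 (0.53 log units; beyond the scatter), but a 2.6-fold lower number from compound 1 to compound 4 (0.42 log units; beyond the scatter). Each step changes the linking oxygen and the ring substituents together, so the contribution of the oxygen alone cannot be read. Nothing available explains these shifts.

On these data alone, whether a 2-chlorophenoxy would match compound 2 and compound 3 remains open. So does the outcome with an amine or a methylene as the link to the terminal ring.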